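A few compounds are considered here, and "the series" means these few. Any claim that something is new, unique, unknown or untested is made for them only; others in the source may bear on it.

Working notes on the series.

Two compounds have numbers in an assay on membranes from CHO cells for displacement of a labelled ligand from adenosine receptor A1 (Homo sapiens), read by scintillation counting, with a stated time of 60 min, tested at 1 uM; a higher number here means more inhibition at the concentration tested (going by the name of the read-out), a lower number less inhibition. Compound 1, `CCN(CC)C(=O)C1=C(C)NC(=O)NC1c1ccsc1`, gives 11% in this assay. Compound 2, `CC1=C(C(=O)OCC2CC2)C(c2ccoc2)NC(=O)N1`, gives 29% in this assay, which is the higher of the two numbers and stands beyond the scatter from compound 1. Going by the values given here, compound 1 and compound 2 differ in two places, so no single step between them can be read.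

The next compound is compound 3, `CC1=C(C(=O)OCC2CC2)C(c2ccsc2)NC(=O)N1`. Compound 3 is compound 2 with thiophen-3-yl in place of furan-3-yl on a saturated ring carbon. Among the compounds with values here, no measured pair shows this change on its own. Compound 1 carries the same thiophen-3-yl group but with another group elsewhere, so its value cannot be read as the effect of this change alone. The step from compound 2 to compound 3 in this assay is expected to be small, a number 1 percentage points higher from compound 2 to compound 3 (within the scatter), not beyond the scatter in either direction. Compound 3 is therefore estimated at 30% in this assay, within a range of 10% to 55%.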

Compound 3, a percentage reported as inhibition, at one concentration (the size of the read-out at that concentration, not a potency): 39%
Compound 3: middle estimate off by 9 percentage points, on the low side; low and high end bracket the measured number.
By their numbers in this assay, from the lowest: compound 1; then compounds 2 and 3 (each within the scatter of the next).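

Thiophen-3-yl in place of furan-3-yl on a saturated ring carbon can now be read on its own in this assay and gives a number 10 percentage points higher from compound 2 to compound 3 (within the scatter), so the compounds shown do not separate these two rings at this position. Going by these compounds alone, with thiophen-3-yl held the same, cyclopropylmethoxy in place of diethylamino on a carbonyl carbon gives a number 28 percentage points higher from compound 1 to compound 3 (beyond the scatter) and this is the only step of the two that lies beyond the scatter. No measurement at hand gives a reason for either step.

The compounds shown do not tell how a phenyl or a pyridin-3-yl group would read on the same saturated ring carbon. They also leave open how a methoxy group or a longer alkoxy chain would read on the carbonyl carbon in place of cyclopropylmethoxy.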